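Swapping a phenoxy for a lactam on a shared core

The source may report more compounds than this note shows. Statements on the series, on what has been measured and on what is new or still open speak of the compounds shown alone.

Three compounds built on one core have been examined in an ADME assay on microsomes from liver (Homo sapiens) for metabolic stability, read by LC-MS, using NADPH, with stated times of 5 min and 30 min, tested at 1 uM; a lower number here means slower removal, a higher number faster removal of the compound. Compound 1, `Fc1ccc2c(c1CNc1ncc(Oc3ccccc3)c3nncn13)CCO2`, gives 18 mL.min-1.g-1 in this assay. Compound 2, `Cc1ncccc1-c1cnc(NCc2c(F)ccc3c2CCO3)c2n[nH]c(=O)n12`, gives 8 mL.min-1.g-1 in this assay, and compound 3, `Cc1nn(C)cc1-c1cnc(NCc2c(F)ccc3c2CCO3)c2cn[nH]c(=O)c12`, gives 27 mL.min-1.g-1 in this assay. Among these three numbers compound 1 stands second highest. Its nearest neighbour is compound 3, whose number is only modestly higher and lies within the usual scatter, so the two cannot be told apart. Its furthest neighbour is compound 2, whose number is low enough to lie beyond the scatter.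

The next compound, compound 4, `C[C@H]1CC(=O)N(c2cnc(NCc3c(F)ccc4c3CCO4)n3cnnc23)C1`, has not yet been measured in this assay. It differs from compound 1 at one point: 4-methyl-2-oxopyrrolidin-1-yl in place of phenoxy on an aromatic carbon. Among the compounds with values here, no pair of measured compounds differs by a single change of this kind, so there is no measured step to lean on. Given the narrow spread of the three measured numbers, compound 4 is expected to show a step from compound 1 of a 1.3-fold lower number from compound 1 to compound 4 (0.11 log units; within the scatter), small and not clearly beyond the scatter. Compound 4 is therefore estimated at 14 mL.min-1.g-1 in this assay, with a plausible range from 6 mL.min-1.g-1 to 32 mL.min-1.g-1.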

Compound 4, intrinsic clearance in microsomes: < 3 mL.min-1.g-1
Compound 4: no number, only a limit (the forecaster's own chance of this, stated with the estimate: 10%); middle value at least 4.6-fold (0.66 log units) from the limit.
By their numbers in this assay, from the lowest: compound 2; then compounds 1 and 3 (each within the scatter of the next). At a limit, below all of these: compound 4.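

In this assay, within the data shown here, putting 4-methyl-2-oxopyrrolidin-1-yl in place of phenoxy on this aromatic carbon gives an at least 6.0-fold lower number from compound 1 to compound 4 (0.77 log units; beyond the scatter), the first single change on the shared core that can be read as a step. The swap keeps the count of 7 heavy atoms and removes the six-membered aromatic ring of carbon only, so a five-membered non-aromatic ring with a carbonyl now sits at this position, two atoms from the ring nitrogen. Compound 4 gives < 3 mL.min-1.g-1, which is a limit of the assay and not a number, so the step shows only a smallest possible size and its true size cannot be read: the limit of < 3 mL.min-1.g-1 in this assay, at which 1 of the 4 values shown sits.

The compounds shown do not separate the contribution of the lactam ring from that of its methyl group or its defined stereocentre, so the plain 2-oxopyrrolidin-1-yl group remains an open comparison at this carbon. From the compounds shown here alone, it also remains open whether a non-lactam group here, such as a morpholine or a dimethylamino group, would give a number nearer to that of compound 1 or to the limit of compound 4.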